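The source may hold more compounds than are shown below. What is called first, only, known or untested is meant among the compounds shown, and "the series" means these compounds.

In a functional assay on Jurkat cells (Homo sapiens) for cytotoxicity, read by MTT assay, with a stated time of 24 h (on this read-out higher numbers stand for an effect only at larger amounts of compound and lower numbers for an effect already at smaller amounts), compound 1 (`CCOC(=O)c1cc([Se]c2ccc(F)cc2)c2cc(OC)ccc2n1`) gives 134000 nM and compound 2 (`CCOC(=O)c1cc([Se]c2ccccc2)c2cc(Cl)ccc2n1`) gives 53000 nM while compound 3 (`CCOC(=O)c1cc([Se]c2ccccc2)c2cc(OC)ccc2n1`) gives 102000 nM on the same core. Compound 3 thus stands within the scatter of both other compounds, so no order among the three can be read. The change to compound 4 (`COc1ccc2nc(-c3c(Cl)cccc3Cl)cc([Se]c3ccccc3)c2c1`) is 2,6-dichlorophenyl in place of ethoxycarbonyl on an aromatic carbon with 2,6-dichlorophenyl in place of ethoxycarbonyl next to the ring nitrogen. The two measured steps are a 1.3-fold lower number from compound 1 to compound 3 (0.12 log units; within the scatter) and a 1.9-fold higher number from compound 2 to compound 3 (0.28 log units; within the scatter) and both lie within the scatter. Neither involves the ethoxycarbonyl, which all three measured compounds carry, so the data give no direct size for this replacement. With only such small steps to go on, no step beyond the scatter is expected in this assay and the uncertainty stays wide. The expected step is a 1.3-fold lower number from compound 3 to compound 4 (0.11 log units; within the scatter) as an estimate only. For compound 4 the estimate is 80000 nM with an expected range from 30000 nM to 200000 nM as a working figure.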

Compound 4, half-maximal effective concentration: 17000 nM
Compound 4: middle estimate off by 4.7-fold (0.67 log units), on the high side; the measured number lies below the stated range.
By their numbers in this assay, from the lowest: compound 4; then compounds 2, 3 and 1 (each within the scatter of the next, the first and the last beyond it).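

In this assay, among the compounds shown here, the place next to the ring nitrogen is the first where a single change moves the number beyond the scatter: 2,6-dichlorophenyl in place of ethoxycarbonyl gives a 6.0-fold lower number from compound 3 to compound 4 (0.78 log units; beyond the scatter). The earlier changes, hydrogen in place of fluoro and methoxy in place of chloro, both stayed within the scatter, so this is the only position shown so far to respond. No measurement at hand bears on the reason for this step.

This one pair does not separate the loss of the ethoxycarbonyl from the gain of the 2,6-dichlorophenyl. It also leaves open whether a carboxylic acid or an amide at this position would give a step of similar size, and whether the step holds with chloro in place of methoxy.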